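A few compounds are considered here, and "the series" means these few. Any claim that something is new, unique, unknown or untested is made for them only; others in the source may bear on it.

Measured so far:
- compound 1, `CC(C)(C)OC(=O)N1CCN(C(=S)SCc2cn(C[C@H](O)[C@H]3OC(=O)C(OCc4ccccc4)=C3OCc3ccccc3)nn2)CC1`: 60 nM
- compound 2, `CCCCCCCCCCc1cn(C[C@H](O)[C@H]2OC(=O)C(OCc3ccccc3)=C2OCc2ccccc2)nn1`: > 100000 nM

The two compounds share a core and differ in the substituent on the five-membered aromatic ring with 3 nitrogen. In an ADME assay on HFF cells (Homo sapiens) for cytotoxicity, read by MTT assay, with a stated time of 72 h (on this read-out lower numbers stand for stronger inhibition and higher numbers for weaker inhibition), compound 1 gives 60 nM. Compound 2 stands apart: in this assay compound 2 gives only a limit, > 100000 nM, and not a number, so it sits at the limit of > 100000 nM in this assay, at which 1 of the 2 values shown sits, the top of what this assay can report.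

Compound 3, `O=C1O[C@H]([C@@H](O)Cn2ccnn2)C(OCc2ccccc2)=C1OCc1ccccc1`, has not been measured. Compared with compound 2, the change is hydrogen in place of decyl on an aromatic carbon. Among the compounds with values here, no measured step of this kind is available, so the expectation rests on compound 2 alone. Since compound 2 already sits at the limit, the step from compound 2 to compound 3 is expected to be a step that the limit leaves unreadable from compound 2 to compound 3, that is, no change beyond the usual scatter, with a real chance that compound 3 also returns only a limit. Compound 3 is therefore estimated at 150000 nM, within a range from 30000 nM to 600000 nM.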

Compound 3, half-maximal inhibitory concentration: 610 nM
The estimate for compound 3 lay 250-fold (2.39 log units) above the measured number; the measured number lies below the stated range.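

Replacing decyl with hydrogen on an aromatic carbon of the five-membered aromatic ring with 3 nitrogen gives, in this assay, an at least 160-fold lower number from compound 2 to compound 3 (2.21 log units; beyond the scatter), so the read-out at this position depends strongly on what the ring carries there. The earlier compounds shown here could not show what the shared core gives with only hydrogen at this place, and compound 3 now supplies that reference with 610 nM, a real number well inside the reach of the assay, so the absence of a readable value for compound 2 does not come with the core alone. Compound 2 holds only a limit, > 100000 nM, so the full size of this step stays unread: the limit of > 100000 nM in this assay, at which 1 of the 3 values shown sits.

On these data alone, what a shorter chain such as butyl would give at this position remains open, as does the outcome for a chain of similar length ending in an amine or a carboxylic acid. The compounds shown also leave open which part of the substituent of compound 1 goes with its value of 60 nM.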